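The source may report more compounds than this note shows. Statements on the series, on what has been measured and on what is new or still open speak of the compounds shown alone.

Measured in a functional assay on KARPAS-422 cells (Homo sapiens) for antiproliferative activity, read by resazurin assay, with a stated time of 72 h; on this read-out lower numbers stand for stronger inhibition and higher numbers for weaker inhibition:
- compound 1 `Cc1cc(C)c(CN2CCc3c(Cl)cc([C@H](CO)[C@H]4CCOC4)c(Cl)c3C2=O)c(=O)[nH]1`: 15 nM
- compound 2 `COc1cc(C)[nH]c(=O)c1CN1CCc2c(Cl)cc(-c3c(C)noc3C)c(Cl)c2C1=O`: 27 nM
- compound 3 `COC(c1cc(Cl)c2c(c1Cl)C(=O)N(Cc1c(C)cc(C)[nH]c1=O)CC2)C1CCN(C2COC2)CC1`: 2260 nM; 25 nM (2 entries)

Among the compounds with values here, compound 1 and compound 2 lie within the scatter of each other, and the reading for compound 1 is the lower of the only two single numbers. Compound 3 offers no single number for comparison: the several entries of compound 3 in this assay, 2260 nM; 25 nM (2 entries).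

The next compound to be measured is compound 4 `Cc1cc(C)c(CN2CCc3c(Cl)cc([C@H](C)CO)c(Cl)c3C2=O)c(=O)[nH]1`. It keeps the core of compound 1 and changes one substituent: a group of 4 heavy atoms (3 carbon, 1 oxygen; no ring) in place of a group of 8 heavy atoms (6 carbon, 2 oxygen; one five-membered non-aromatic ring with 1 hetero atom), on an aromatic carbon. The 1-(hydroxymethyl)ethyl group, with no ring, enters in place of the group with the five-membered non-aromatic ring. The place is an aromatic carbon ortho to a chloro group.

Within the data shown here, no pair of measured compounds differs in one place, and no measured step shows what this change does. The expectation rests only on compound 1 at 15 nM and on the size of the change, which removes the ring and half of the heavy atoms in the group. In this assay, a moderate rise towards weaker inhibition, probably beyond the scatter, is expected for a 5.3-fold higher number from compound 1 to compound 4 (0.73 log units; beyond the scatter). Compound 4 is estimated at 80 nM, with an expected range of 20 nM to 320 nM.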

Compound 4, half-maximal inhibitory concentration: 186 nM
The estimate for compound 4 lay 2.3-fold (0.37 log units) below the measured number, and the stated range covers the measured number.
By their numbers in this assay, from the lowest: compounds 1 and 2 (each within the scatter of the next); then compound 4.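

In this assay, within the data shown here, the aromatic carbon ortho to a chloro group turns out to be sensitive to the group it carries: the 1-(hydroxymethyl)ethyl group, entering in place of the group with the five-membered non-aromatic ring, gives a 12-fold higher number from compound 1 to compound 4 (1.09 log units; beyond the scatter) in a single change, the first measured step at this place. The hydrogen-bond donor count stays the same across this step, while the ring, the acceptor count, the heavy-atom count and the number of defined stereocentres all change, so keeping the donor count alone does not preserve the number seen for compound 1. Nothing measured here ties the step to any one of these differences.

Still open, on these data alone, is whether the ring itself, its oxygen or simply the size of the group accounts for the step, which a cyclopentyl ring or a longer chain ending in a hydroxyl group at this place could help separate. Also open, as far as these compounds go, is how this place responds to an amine or a carboxylic acid on the side chain, and whether the opposite configuration of the stereocentre in compound 4 changes the reading.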